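Adding an Amino Group: From Compound 3 to Compound 4

The compounds below may be only part of what the source reports. "The series", "measured", "known", "first", "only" and "open" are said of these compounds alone.

Compound 1, `ClCc1ccc(Cn2cnc3c(Cl)ncnc32)cc1`, gives 2910 nM in a functional assay on K562 cells (Homo sapiens) for cytotoxicity, read by sulforhodamine B assay, with a stated time of 48 h; a lower number here means a stronger inhibitor of growth, a higher number a weaker inhibitor of growth.
Compound 2, `Nc1nc(Cl)c2ncn(Cc3ccc(CCl)cc3)c2n1`, gives 3630 nM in this assay.
Compound 3, `ClCc1ccccc1Cn1cnc2c(Cl)ncnc21`, gives 1200 nM in this assay.

Compound 2 differs from compound 1 in one place: amino in place of hydrogen on an aromatic carbon. That change moved the number by a 1.2-fold higher number from compound 1 to compound 2 (0.10 log units; within the scatter), so the two compounds behave alike in this assay.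

Compound 3 is built from the same atoms as compound 1, joined differently; the difference between the two cores is not broken down here. Compound 3 has the lowest number of the three, and its gap to compound 1 and to compound 2 lies beyond the scatter in each case.

Compound 4, `Nc1nc(Cl)c2ncn(Cc3ccccc3CCl)c2n1`, has not yet been measured. It differs from compound 3 by amino in place of hydrogen on an aromatic carbon, the same change that turned compound 1 into compound 2. Because that earlier change gave a 1.2-fold higher number from compound 1 to compound 2 (0.10 log units; within the scatter), the step from compound 3 to compound 4 is expected to be a 1.2-fold higher number from compound 3 to compound 4 (0.08 log units; within the scatter). Compound 4 is therefore estimated at 1450 nM, likely between 700 nM and 3000 nM.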

Compound 4, concentration for 50% growth inhibition: 4470 nM
The estimate for compound 4 lay 3.1-fold (0.49 log units) below the measured number; the whole stated range lies below it.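

In this assay, putting amino in place of hydrogen on an aromatic carbon of the core of compound 3 gave a 3.7-fold higher number from compound 3 to compound 4 (0.57 log units; beyond the scatter), so on this core the added group goes with weaker growth inhibition. The same swap did not carry over at the same size from one core to the other: the same change on two cores in this assay, a 1.2-fold higher number (0.10 log units; within the scatter) from compound 1 to compound 2 and a 3.7-fold higher number (0.57 log units; beyond the scatter) from compound 3 to compound 4, 3.0-fold (0.48 log units) apart, beyond the scatter of two such steps. The two pairs show that a step seen on one core cannot simply be transferred to a closely related core in this series, but two pairs give no rule for a third core, and they do not show why the cores part.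

The compounds shown leave open whether another group on that same aromatic carbon, such as a methylamino or a methoxy group, would also separate the two cores. They also leave open whether the gap between the cores would persist if an amine replaced the chloro group.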